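Aryl swap on the oxadiazole-linked thiazolidinedione series

A few compounds are considered here, and "the series" means these few. Any claim that something is new, unique, unknown or untested is made for them only; others in the source may bear on it.

The series shares one core, a thiazolidinedione joined through an ether chain and a sulfur link to a five-membered aromatic ring that carries an aryl group. Compound 1 `O=C1NC(=O)/C(=C/c2ccc(OCCSc3nnc(-c4ccccc4[N+](=O)[O-])[nH]3)cc2)S1` bears a 2-nitrophenyl on that ring and in a functional assay on the whole organism (strain Wistar) with Rattus norvegicus as the target, with a stated time of 15 days, at a dose of 100 mg/kg by the oral route (on this read-out higher numbers stand for a stronger effect at the one dose given and lower numbers for a weaker effect), compound 1 gives 49.1%. Compound 2 `COc1ccc(-c2nnc(SCCOc3ccc(/C=C4\SC(=O)NC4=O)cc3)[nH]2)cc1` carries a 4-methoxyphenyl instead, and compound 2 gives 71.2%; the change is a number 22.1 percentage points higher from compound 1 to compound 2 (beyond the scatter). Compound 3 `O=C1NC(=O)/C(=C/c2ccc(OCCSc3nnc(-c4ccccc4)o3)cc2)S1` has an unsubstituted phenyl on a five-membered aromatic ring with 2 nitrogen and 1 oxygen, and compound 3 gives 33.1%, the lowest of the three numbers, with the gap to compound 1 and to compound 2 both beyond the scatter.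

Compound 4 `O=C1NC(=O)/C(=C/c2ccc(OCCSc3nnc(-c4cccnc4)o3)cc2)S1` differs from compound 3 in one place: pyridin-3-yl in place of phenyl on an aromatic carbon. For the measured compounds named here, no measured step touches a pyridin-3-yl, and the only step on record, from a 2-nitrophenyl to a 4-methoxyphenyl on a different five-membered ring, does not speak to this change. Without a comparable pair, the expectation is a step of no clear direction, a number 2.9 percentage points higher from compound 3 to compound 4 (within the scatter), within the scatter. Compound 4 is therefore estimated at 36%, with a range from 20% to 55%.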

Compound 4, a percentage reported as activity, at one dose (the size of the read-out at that dose, not a potency): 72.3%
Estimate against measurement, compound 4: 36.3 percentage points below, outside the stated range (above it).
By their numbers in this assay, from the lowest: compound 3; then compound 1; then compounds 2 and 4 (each within the scatter of the next).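

Working notes on the aryl position: on the five-membered aromatic ring with 2 nitrogen and 1 oxygen, pyridin-3-yl in place of phenyl gives in this assay a step of a number 39.2 percentage points higher from compound 3 to compound 4 (beyond the scatter) and is rated large. The aryl groups in this pair differ only in that a ring carbon becomes a ring nitrogen, with the heavy-atom count unchanged, so this position responds strongly to a change inside the aryl ring itself and needs no added substituent to do so. Nothing available here bears on what lies behind this step.

Pyridin-2-yl and pyridin-4-yl would show whether the place of the ring nitrogen matters, and an amine or a carboxylic acid on the phenyl of compound 3 would show whether other nitrogen- or oxygen-bearing groups at this position move the read-out in the same direction. For the compounds shown here, it also remains open whether pyridin-3-yl would give a step of similar size on the other five-membered ring, the one carried by compound 1 and compound 2.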